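This account rests on a few compounds, and the source may have more. Where it says the series, first, only, none or still open, it means among the compounds named here.

The measured compounds:

Compound 1, `CCN(CC)c1cc2[nH]c(C3CCCCC3)nc2cc1NC(=O)NCc1ccccc1`. In an ADME assay on Vero cells (Chlorocebus sabaeus) for cytotoxicity, read by resazurin assay, with a stated time of 3 days (on this read-out higher numbers stand for weaker inhibition and lower numbers for stronger inhibition), compound 1 gives > 100 ug/mL, which is a limit of the assay rather than a number.
Compound 2, `COc1ccc(C(=O)Nc2cc3nc(C4CCCCC4)[nH]c3cc2N(C)C)cc1`. In this assay compound 2 gives > 100 ug/mL, again a limit.
Compound 3, `O=C(NCc1ccccc1)Nc1cc2nc(C3CCCCC3)[nH]c2cc1N1CCCC1`. In this assay compound 3 gives > 100 ug/mL, also a limit.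

Compound 1 therefore has no exact number of its own; it sits at the limit of > 100 ug/mL in this assay, at which 3 of the 3 values shown sit, together with the other two measured compounds. Among the compounds with values here, the only measured change that alters a single place, from compound 1 to compound 3, gives a step that the two limits leave unreadable from compound 1 to compound 3, so it tells nothing about the size of any step.

The compound still to be measured, compound 4, is `CCOCCOC(=O)Nc1cc2nc(C3CCCCC3)[nH]c2cc1N(CC)CC`. It differs from compound 1 in one place: 2-ethoxyethoxy in place of benzylamino on a carbonyl carbon. Within the data shown here, no measured step bears on this change, because a step that the two limits leave unreadable from compound 1 to compound 3 cannot be read and every value shown is a limit. With all three measured compounds at the limit, no step beyond the usual scatter can be expected in either direction. For compound 4 the estimated value in this assay is 100 ug/mL, with a range from 50 ug/mL to 200 ug/mL, and the step expected from compound 1 is a number no higher from compound 1 to compound 4 (the limit leaves the size open), most likely again reported only as a limit.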

Compound 4, half-maximal inhibitory concentration: > 100 ug/mL
Compound 4: a limit, no number; the forecaster's own chance of this, stated with the estimate: 85%; the middle value lies on the limit itself.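

Compound 4, like compound 1, gives only a limit and not a number, so no step from one to the other can be read, and the same holds across all the compounds shown: the limit of > 100 ug/mL in this assay, at which 4 of the 4 values shown sit. The compounds shown leave open what exact value each has in this assay and whether 2-ethoxyethoxy in place of benzylamino changes that value at all.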